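The source may report more compounds than this note shows. Statements on the series, on what has been measured and on what is new or still open speak of the compounds shown alone.

Compounds measured so far in a functional assay on cells (Panel colon (Carcinoma cell lines), Homo sapiens) for inhibition, read by sulforhodamine B assay, with a stated time of 48 h; on this read-out higher numbers stand for weaker inhibition of growth and lower numbers for stronger inhibition of growth:
compound 1 `CN1CCN(CCCOc2cccc3nc(Nc4ccc(Cl)c(C(F)(F)F)c4)ccc23)CC1` gives 1580 nM
compound 2 `CN1CCN(CCCOc2cccc3nc(Nc4cc(Cl)cc(Cl)c4)ccc23)CC1` gives 1680 nM

Compound 2 holds the highest number of the two, but the gap to compound 1 is within the scatter: a 1.1-fold higher number from compound 1 to compound 2 (0.03 log units; within the scatter). Exchanging one disubstituted aryl group on the ring nitrogen for another therefore left this assay essentially unmoved.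

Compound 3 `CN1CCN(CCCOc2cccc3nc(Nc4cccc(Cl)c4)ccc23)CC1` is not yet measured. It differs from compound 2 by hydrogen in place of chloro on an aromatic carbon; the place is an aromatic carbon of a six-membered aromatic ring of carbon only, meta to a chloro group and meta to a large group. Going by the values given here, no measured pair shows removal of a substituent from this aryl ring; the single step from compound 1 to compound 2 only shows that swapping between two halogenated patterns stays within the scatter. Loss of one chloro is expected to weaken growth inhibition slightly, by a 1.5-fold higher number from compound 2 to compound 3 (0.17 log units; within the scatter), though a result within the scatter would not surprise. Compound 3 is estimated at 2500 nM, range 1000 nM to 6000 nM.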

Compound 3, concentration for 50% growth inhibition: 1640 nM
Compound 3: the middle estimate sits 1.5-fold (0.18 log units) above what was measured; measured number inside the range.
By their numbers in this assay, from the lowest: compounds 1, 3 and 2 (each within the scatter of the next).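

In this assay, going by these compounds alone, the change from 3,5-dichlorophenyl to 3-chlorophenyl gives a 1.0-fold lower number from compound 2 to compound 3 (0.01 log units; within the scatter) and is the first removal of a substituent from this aryl ring. Against the 4-chloro-3-(trifluoromethyl)phenyl group, 3-chlorophenyl gives a 1.0-fold higher number from compound 1 to compound 3 (0.02 log units; within the scatter) in this assay as well, so a single chloro on this ring reads the same as either disubstituted pattern. No supporting data are available to explain this flat response.

Going by these compounds, whether the remaining chloro matters stays open: a plain phenyl group could read differently, as could a methoxy group, a nitrile or a carboxylic acid on this ring. Also open, on these data alone, is whether any change on this ring moves the number, or whether the aryl group as a whole can be replaced, for example by a cyclohexyl group.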